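A few compounds are considered here, and "the series" means these few. Any claim that something is new, unique, unknown or untested is made for them only; others in the source may bear on it.

Values so far in a functional assay on HCT-116 cells (Homo sapiens) for antiproliferative activity, read by CCK-8 assay, with a stated time of 72 h; a higher number here means a weaker inhibitor, a lower number a stronger inhibitor
compound 1 `Nc1ccccc1NC(=O)c1ccc(CSc2cccc(F)c2)cc1` gives 2870 nM
compound 2 `Nc1ccccc1NC(=O)c1ccc(CSCCc2ccccc2)cc1` gives 2810 nM
compound 3 `Nc1ccccc1NC(=O)c1ccc(CSc2ccc(F)cc2)cc1` gives 4010 nM

Compound 3 sits level with the other two, with a 1.4-fold higher number from compound 1 to compound 3 (0.15 log units; within the scatter) and a 1.4-fold higher number from compound 2 to compound 3 (0.15 log units; within the scatter) both within the scatter. Among the compounds with values here, compound 4 `Cc1cc(C)cc(SCc2ccc(C(=O)Nc3ccccc3N)cc2)c1` has 3,5-dimethylphenyl in place of 4-fluorophenyl on a sulfur and no measured compound carries that group. The measured swaps on this sulfur, those two steps and a 1.0-fold lower number from compound 1 to compound 2 (0.01 log units; within the scatter) as well, all stayed within the scatter, so no step beyond it is expected in this assay and no direction is favoured. The estimate amounts to a 1.2-fold lower number from compound 3 to compound 4 (0.08 log units; within the scatter) as an expected step within the scatter. Compound 4 is expected near 3300 nM with an estimated range from 1600 nM to 6500 nM in this read-out.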

Compound 4, half-maximal inhibitory concentration: 2490 nM
Compound 4: middle estimate off by 1.3-fold (0.12 log units), on the high side, within the range that was stated.
By their numbers in this assay, from the lowest: compounds 4, 2, 1 and 3 (each within the scatter of the next).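

In this assay the change from fluorine to two methyl groups on the aromatic ring leaves the number level, with a 1.6-fold lower number from compound 3 to compound 4 (0.21 log units; within the scatter) and a 1.2-fold lower number from compound 1 to compound 4 (0.06 log units; within the scatter) and a 1.1-fold lower number from compound 2 to compound 4 (0.05 log units; within the scatter) all inside the scatter. Four different groups on this sulfur now give no step beyond the scatter, and that includes the largest step seen so far at this position, from 4-fluorophenyl to 3,5-dimethylphenyl. No measurement at hand explains this flat response.

Open, going by these compounds, is whether an amine, a carboxylic acid or a chain longer than phenethyl on this sulfur would move the number beyond the scatter.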